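The source may report more compounds than this note shows. Statements on the series, on what has been measured and on what is new or still open speak of the compounds shown alone.

Of the compounds shown here, three share one core and have been tested in a functional assay on MIA PaCa-2 cells (Homo sapiens) for cytotoxicity; on this read-out higher numbers stand for weaker inhibition and lower numbers for stronger inhibition. Compound 1 `COc1ccc2c(c1)c(/C=N\NC(=O)c1c[nH]c3ccccc13)cn2Cc1ccc(Cl)cc1` gives 26700 nM. Compound 2 `O=C(N/N=C\c1cn(Cc2ccc(Cl)cc2)c2cc(F)ccc12)c1c[nH]c2ccccc12` gives 18000 nM, the lowest of the three numbers, though its gap to compound 1 lies within the scatter. Compound 3 `COc1ccc(Cn2cc(/C=N\NC(=O)c3c[nH]c4ccccc34)c3ccc(F)cc32)cc1` gives 43300 nM, the furthest from compound 2. Among the measured compounds shown here, the one single-point step among them, a 2.4-fold higher number from compound 2 to compound 3 (0.38 log units; beyond the scatter), concerns the group on the benzyl ring, not the core.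

Compound 4 `O=C(N/N=C\c1cn(Cc2ccc(Cl)cc2)c2ccccc12)c1c[nH]c2ccccc12` differs from compound 2 in one place: hydrogen in place of fluoro on an aromatic carbon. For the measured compounds named here, no measured step removes a fluoro from the core, so the step from compound 2 to compound 3 bears on it only by showing how modest a single change here can be. Going by the values given here, with no direct precedent, the expected change is none beyond the scatter, so the number for compound 4 is estimated near that of compound 2, at 20000 nM within a range from 9000 nM to 45000 nM. That estimate means a step of a 1.1-fold higher number from compound 2 to compound 4 (0.05 log units; within the scatter) is expected.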

Compound 4, half-maximal inhibitory concentration: 44300 nM
Compound 4: middle estimate off by 2.2-fold (0.35 log units), on the low side; low and high end bracket the measured number.
By their numbers in this assay, from the lowest: compounds 2, 1, 3 and 4 (each within the scatter of the next, the first and the last beyond it).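

In this assay, among the compounds shown here, the fluoro on the shared core proves not to be a silent passenger: with hydrogen in its place there is a 2.5-fold higher number from compound 2 to compound 4 (0.39 log units; beyond the scatter), a modest shift towards weaker inhibition, and the first step beyond the scatter that involves the core rather than the benzyl ring. Hydrogen in place of methoxy on the core, by contrast, gives a 1.7-fold higher number from compound 1 to compound 4 (0.22 log units; within the scatter), so that change cannot be told apart from repeat-measurement noise, and the two core substituents do not behave alike relative to hydrogen. Nothing available explains the effect of the fluoro.

Going by these compounds, it remains open whether chloro or a nitrile on the same aromatic carbon would match fluoro. Also open, on these data alone, is whether a methoxy there would resemble hydrogen or fluoro.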